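Thienylthio series: replacing furan-2-yl with methyl

A few compounds are considered here, and "the series" means these few. Any claim that something is new, unique, unknown or untested is made for them only; others in the source may bear on it.

Hmm, the title must name no ring that the data do not print, so the working title is:

Furan-2-yl to methyl on the shared core

- compound 1 `CN(C)c1ncnc2[nH]cc(Sc3cccs3)c12`: 19800 nM
- compound 2 `Nc1ncnc2[nH]cc(Sc3cccs3)c12`: 22800 nM
- compound 3 `c1coc(-c2ncnc3[nH]cc(Sc4cccs4)c23)c1`: 11400 nM
- compound 4 `Cc1ncnc2[nH]cc(Sc3cccs3)c12`: not yet measured

All values come from a functional assay on A549 cells (Homo sapiens), read by MTT assay, with a stated time of 3 days; on this read-out lower numbers stand for stronger inhibition and higher numbers for weaker inhibition. Compound 3 is not separated from the other two compounds, as a 1.7-fold lower number from compound 1 to compound 3 (0.24 log units; within the scatter) and a 2.0-fold lower number from compound 2 to compound 3 (0.30 log units; within the scatter) both stay within the scatter. The next change is methyl in place of furan-2-yl on an aromatic carbon, which leads to compound 4: methyl in place of furan-2-yl on an aromatic carbon.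

For the measured compounds named here, no methyl compound has been measured in this assay, so the evidence is indirect. The two steps above bring furan-2-yl in at this same place, and both are small. The exchange of the other two groups, a 1.2-fold higher number from compound 1 to compound 2 (0.06 log units; within the scatter), is also small. Across the three groups at this place, the numbers have so far stayed close together, although three compounds are a narrow basis. The expected change, a 1.5-fold higher number from compound 3 to compound 4 (0.17 log units; within the scatter), is therefore none beyond the scatter, with no firm direction. Compound 4 is estimated at 17000 nM, with an expected range from 9000 nM to 32000 nM.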

Compound 4, half-maximal inhibitory concentration: > 50000 nM
Compound 4: a limit, no number (the forecaster's own chance of this, stated with the estimate: 8%); at least 2.9-fold (0.46 log units) between middle value and limit.
By their numbers in this assay, from the lowest: compounds 3, 1 and 2 (each within the scatter of the next). At a limit, above all of these: compound 4.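

In this assay compound 4 stands at a limit and not at a number: the limit of > 50000 nM in this assay, at which 1 of the 4 values shown sits.

This place on the shared core is not indifferent to the group it carries: the steps of an at least 4.3-fold higher number from compound 3 to compound 4 (0.64 log units; beyond the scatter) and an at least 2.1-fold higher number from compound 2 to compound 4 (0.34 log units; beyond the scatter) and an at least 2.5-fold higher number from compound 1 to compound 4 (0.40 log units; beyond the scatter) all lie beyond the scatter, whereas the earlier exchanges among dimethylamino, amino and furan-2-yl all stayed within it. Methyl is thus the only one of the four groups that separates from the others, so the closeness of the first three numbers does not extend to every group at this place, and each of the three steps gives only a lower bound on its size.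

The compounds shown leave open whether a longer chain such as ethyl, a methoxy group or a phenyl ring at this place would stay with compound 1, compound 2 and compound 3 or fall with compound 4. They also leave open how far beyond its limit compound 4 lies, and whether any group here can give a number clearly lower than those of the first three compounds.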